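Notes on the amide-nitrogen change in the vinyl furan series

The source may report more compounds than this note shows. Statements on the series, on what has been measured and on what is new or still open speak of the compounds shown alone.

Measured compounds:
- compound 1 `C=CC1=C(C(=O)Nc2ccc(OCC)cc2)C(c2ccc(OC)cc2)OC1`: in a functional assay on SW480 cells (Homo sapiens) for cytotoxicity, read by MTT assay, with a stated time of 24 h (on this read-out lower numbers stand for stronger inhibition and higher numbers for weaker inhibition), compound 1 gives > 100000 nM, a limit of the assay and not a number.
- compound 2 `C=CC1=C(C(=O)NCCCCC)C(c2ccc(F)cc2)OC1`: compound 2 gives > 100000 nM, likewise a limit.
- compound 3 `C=CC1=C(C(=O)Nc2ccc(OCC)cc2)C(c2ccc(F)cc2)OC1`: compound 3 gives > 100000 nM, likewise a limit.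

Compound 1 therefore has no number of its own in this assay, only a limit; every value in the set is the same limit, as summarised by the limit of > 100000 nM in this assay, at which 3 of the 3 values shown sit. Among the compounds with values here, the single step between measured neighbours, a step that the two limits leave unreadable from compound 1 to compound 3, is unreadable for that reason.

Compound 4 `C=CC1=C(C(=O)NCCC)C(c2ccc(OC)cc2)OC1` differs from compound 1 by propyl in place of 4-ethoxyphenyl on an amide-type nitrogen. Within the data shown here, no measured pair covers that change: compound 2 carries a pentyl on the amide nitrogen and compound 1 an ethoxyphenyl, and both values are limits, so they show only that neither reaches a readable inhibition. With nothing pointing away from the limit, compound 4 is expected to stay there, the step that the limit leaves unreadable from compound 1 to compound 4 being an estimate of no readable change. The estimated value for compound 4 is 150000 nM, within a range of 60000 nM to 500000 nM.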

Compound 4, half-maximal inhibitory concentration: > 100000 nM
Compound 4 ended at the assay's limit; the forecaster's own chance of this, stated with the estimate: 90%; the middle value is on the limit's open side.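

Compound 1 and compound 4 both stand only at a limit, not at a number, so no step can be read between them: the limit of > 100000 nM in this assay, at which 4 of the 4 values shown sit.

Still open, from the compounds shown here alone, is how far each compound lies past that limit, and whether propyl and 4-ethoxyphenyl on the amide-type nitrogen differ at all.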